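Swapping trifluoromethyl for methyl on two related cores

A few compounds are considered here, and "the series" means these few. Any claim that something is new, unique, unknown or untested is made for them only; others in the source may bear on it.

Of the compounds shown here, three have been measured in a physicochemical assay for acid dissociation. Compound 1 `CN1C=CN(C2OC(C(F)(F)F)=CN2c2ccc(S(N)(=O)=O)cc2)C=C1` gives 7.18 in this assay. Compound 2 `CC1=CN(c2ccc(S(N)(=O)=O)cc2)C(N2C=CN(C)C=C2)O1` differs from it by methyl in place of trifluoromethyl on a double-bonded ring carbon, and in this assay compound 2 gives 7.01. The step of a number 0.17 log units lower from compound 1 to compound 2 (within the scatter) is therefore small. Compound 3 `CN1C=CN(C2SC(C(F)(F)F)=CN2c2ccc(S(N)(=O)=O)cc2)C=C1` is built on a different core; how the two cores differ is not broken down here. In this assay compound 3 gives 7.5, which is the highest of the three numbers, standing beyond the scatter above compound 1 and further still above compound 2.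

Compound 4 `CC1=CN(c2ccc(S(N)(=O)=O)cc2)C(N2C=CN(C)C=C2)S1` has not yet been measured. It is related to compound 3 by methyl in place of trifluoromethyl on a double-bonded ring carbon. Among the compounds with values here, this is the same kind of change as the one from compound 1 to compound 2, but the surroundings are not identical: in compound 1 the changed carbon sits in a five-membered non-aromatic ring with one nitrogen and one oxygen, next to the ring oxygen, whereas in compound 3 the ring holds one nitrogen and one sulfur and the changed carbon is next to the ring sulfur.

Because the earlier step of a number 0.17 log units lower from compound 1 to compound 2 (within the scatter) stayed within the scatter, the step from compound 3 to compound 4 is expected to be similarly small, about a number 0.17 log units lower from compound 3 to compound 4 (within the scatter). Compound 4 is accordingly estimated to give 7.33 in this assay, most likely between 7 and 7.65.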

Compound 4, acid dissociation constant: 7.2
For compound 4 the middle estimate is 0.13 log units above the measured one; low and high end bracket the measured number.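

In this assay methyl in place of trifluoromethyl on a double-bonded ring carbon now gives a number 0.30 log units lower from compound 3 to compound 4 (within the scatter) and, on the other core, a number 0.17 log units lower from compound 1 to compound 2 (within the scatter); the change has now been read on two cores, and on both the read-out falls within the ordinary spread of repeat measurements. This shows that, for these two pairs, the swap carries from one core to the other without producing a step that can be told apart from that spread, but it does not show that the swap has a real effect on the read-out in either pair, and two pairs cannot establish a rule for the whole series or for a third core. Nothing measured here gives any explanation for either step.

The compounds shown leave open whether a different group on that same double-bonded ring carbon, such as a nitrile, a chlorine atom or an ethyl chain, would give a step beyond the scatter. They also leave open whether the methyl swap stays this small when an amine or a carboxylic acid replaces the group on the ring atom that bears a group of 7 heavy atoms.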